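Swapping Methyl for Chloro: What to Expect

The source may hold more compounds than are shown below. What is called first, only, known or untested is meant among the compounds shown, and "the series" means these compounds.

In a functional assay on NCI-H460 cells (Homo sapiens) for cytotoxicity, read by MTT assay, with a stated time of 68 h (a higher number here means a weaker inhibitor, a lower number a stronger inhibitor), compound 2 `Cc1ccc(-c2cccc(NC(=O)C(Cl)Cl)c2)cc1` gives 8000 nM. Compound 3 `CCOc1cccc(-c2cc(NC(=O)C(Cl)Cl)cc(-c3cccc(OCC)c3)c2)c1` gives 4950 nM, and these two numbers lie within the usual scatter of each other, so they cannot be told apart. Compound 1 `Nc1cccc(-c2cccc(NC(=O)C(Cl)Cl)c2)c1` returns only a limit of the assay, > 50000 nM, and not a number.

Compound 4 `O=C(Nc1cccc(-c2ccc(Cl)cc2)c1)C(Cl)Cl` has not been measured yet. It differs from compound 2 at a single place, with chloro in place of methyl on an aromatic carbon, para to a large group (chloro in place of methyl on an aromatic carbon). Within the data shown here, no two measured compounds here differ in only one place, so the data give no direct size for a swap of this kind. With one heavy atom leaving and one entering, and no ring or net charge involved, the reasonable starting point is compound 2 at 8000 nM, and only a small shift from it is expected. The estimated change is a 1.3-fold lower number from compound 2 to compound 4 (0.12 log units; within the scatter), a slight move towards a lower number that would stay within the scatter. For compound 4 the expected value is 6000 nM, with an estimated range from 2500 nM to 15000 nM.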

Compound 4, half-maximal inhibitory concentration: > 50000 nM
Compound 4: only a limit was reported; the forecaster's own chance of this, stated with the estimate: 8%; middle value at least 8.3-fold (0.92 log units) from the limit.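

In this assay, putting chloro in place of methyl on an aromatic carbon, para to a large group, gives an at least 6.2-fold higher number from compound 2 to compound 4 (0.79 log units; beyond the scatter). Among these compounds, this is the first single-place step available in this set, and it shows that a change this small can carry a step beyond the scatter at this position: one heavy atom leaves and one enters, no ring is involved, neither group has hydrogen-bond donors or acceptors, and neither carries a net charge. The value of compound 4 is a limit of the assay and not a number, so the step sets only a minimum size, and the same limit appears elsewhere in this small set: the limit of > 50000 nM in this assay, at which 2 of the 4 values shown sit.

How far compound 4 really lies from compound 2 cannot be read from these compounds, and this single swap gives no rule for other positions or for other cores. As far as these compounds go, how a fluoro group or a carboxylic acid at this same place would read in this assay also stays open, so it is unclear whether methyl is unusual here or chloro is.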